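Dimethylamino for Trifluoromethyl on a Biaryl Sulfonamide

The source may report more compounds than this note shows. Statements on the series, on what has been measured and on what is new or still open speak of the compounds shown alone.

Compound 1 `O=S(=O)(Nc1cccc(CO)c1)c1ccc(-c2ccc3[nH]ccc3c2)cc1`: > 5000 nM
Compound 2 `O=S(=O)(Nc1cccc(CO)c1)c1ccc(-c2ccc3cc[nH]c3c2)cc1`: 2500 nM
Compound 3 `O=S(=O)(Nc1cccc(CO)c1)c1ccc(-c2ccc(C(F)(F)F)cc2)cc1`: 2500 nM

All three were tested in a functional assay on J774 cells (Mus musculus) for cytotoxicity, read by resazurin assay, with a stated time of 72 h; on this read-out lower numbers stand for stronger inhibition and higher numbers for weaker inhibition. For compound 1 the figure is not a number but a limit of the assay, namely (the limit of > 5000 nM in this assay, at which 1 of the 3 values shown sits). From compound 1 to compound 2 the change is an at least 2.0-fold lower number from compound 1 to compound 2 (0.30 log units; that floor lies within the scatter). Compound 3 sits level with compound 2 at the digits shown, and the two values lie within the scatter of each other.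

Compound 4 `CN(C)c1ccc(-c2ccc(S(=O)(=O)Nc3cccc(CO)c3)cc2)cc1` differs from compound 3 by dimethylamino in place of trifluoromethyl on an aromatic carbon. Among the measured compounds shown here, the only measured step concerns the indolyl attachment and leaves the trifluoromethyl group untouched, so no measured step bears on this change. Compound 4 is therefore expected to show no step beyond the scatter, that is no change at the digits printed from compound 3 to compound 4 (within the scatter). The estimate for compound 4 in this assay is 2500 nM, with a range from 900 nM to 7000 nM.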

Compound 4, half-maximal inhibitory concentration: > 5000 nM
Compound 4: no number, only a limit; the forecaster's own chance of this, stated with the estimate: 25%; middle value at least 2.0-fold (0.30 log units) away from the limit.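

For compound 4 the read-out in this assay is a limit of the assay and not a number: the limit of > 5000 nM in this assay, at which 2 of the 4 values shown sit. This is the first change shown at this position, on an aromatic carbon para to a large group, and replacing trifluoromethyl with dimethylamino gives an at least 2.0-fold higher number from compound 3 to compound 4 (0.30 log units; that floor lies within the scatter), while the change of the whole aryl group gives an at least 2.0-fold higher number from compound 2 to compound 4 (0.30 log units; that floor lies within the scatter). So neither step points toward a lower number, though both are only floors, and the step that links the two compounds at the limit cannot be read.

On these data alone, how far compound 4 actually lies beyond its limit stays open. Also open, as far as these compounds go, is how a carboxylic acid or a primary amine at this same position would read in this assay, and whether either would separate from compound 3 by more than the scatter.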